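The compounds below may be only part of what the source reports. "The series", "measured", "known", "first", "only" and "open" are said of these compounds alone.

In an assay on isolated protein for binding affinity to adenosine receptor A1 (Bos taurus) (a lower number here means a stronger inhibitor, a higher number a weaker inhibitor), compound 1 `CCCCCCNc1nc(-c2ccccc2)nc2c1nnn2Cc1ccccc1` gives 13200000 nM, the lower of the two numbers at hand. Among the measured compounds shown here, compound 2 `CCNc1nc(-c2ccccc2)nc2c1nnn2Cc1ccccc1Cl` gives 463000000 nM in this assay, a number that sits beyond the scatter above the one for compound 1. Compound 3 `c1ccc(Cn2nnc3c(NC4CCCC4)nc(-c4ccccc4)nc32)cc1` has not yet been measured; it differs from compound 1 by cyclopentyl in place of hexyl on a nitrogen on an aromatic ring. For the measured compounds named here, no measured pair shows this change, so the step in this assay is only an expectation: it is estimated at a 2.6-fold lower number from compound 1 to compound 3 (0.42 log units; beyond the scatter), a modest move toward a lower number. Compound 3 is therefore expected to give 5000000 nM, within a range from 1000000 nM to 25000000 nM.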

Compound 3, inhibition constant: 11000000 nM
For compound 3 the middle estimate is 2.2-fold (0.34 log units) below the measured one, within the range that was stated.
By their numbers in this assay, from the lowest: compounds 3 and 1 (each within the scatter of the next); then compound 2.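

With cyclopentyl in place of hexyl on a nitrogen on an aromatic ring, this assay gives a 1.2-fold lower number from compound 1 to compound 3 (0.08 log units; within the scatter), so at this position the ring and the open chain cannot be told apart. Among the compounds shown here, this is the first pair that differs in this one place, and it shows that these two carbon-only groups read alike here. Nothing at hand speaks to the reason for this.

From the compounds shown here alone, whether a cyclohexyl ring, or a chain carrying a hydroxyl or an amine, would read the same on this nitrogen remains open.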